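Adding a Second Fluorine to the Benzoyl Ring

This account rests on a few compounds, and the source may have more. Where it says the series, first, only, none or still open, it means among the compounds named here.

Three compounds built on one shared core differ only in the aromatic ring attached to a carbonyl carbon. Compound 1 has the structure `CN(C(=O)NC(=O)c1ccc(F)c(F)c1)c1nc(C(F)(F)F)c(C(=O)N/N=C/c2ccccc2C(F)(F)F)s1`, and in a functional assay on HeLa cells (Homo sapiens) for inhibition, read by MTT assay, with a stated time of 72 h (a lower number here means a stronger inhibitor, a higher number a weaker inhibitor), compound 1 gives 9.24 ug/mL. Compound 2, `CN(C(=O)NC(=O)c1ccc(Cl)cc1Cl)c1nc(C(F)(F)F)c(C(=O)N/N=C/c2ccccc2C(F)(F)F)s1`, gives 9 ug/mL. Compound 3, `CN(C(=O)NC(=O)c1ccccc1F)c1nc(C(F)(F)F)c(C(=O)N/N=C/c2ccccc2C(F)(F)F)s1`, gives 10.1 ug/mL, the highest of the three numbers, yet all three lie within the usual scatter of one another: a 1.0-fold lower number from compound 1 to compound 2 (0.01 log units; within the scatter), a 1.1-fold higher number from compound 1 to compound 3 (0.04 log units; within the scatter), and a 1.1-fold higher number from compound 2 to compound 3 (0.05 log units; within the scatter). Swapping halogens around this ring has so far produced no step beyond the scatter.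

Compound 4, `CN(C(=O)NC(=O)c1c(F)cccc1F)c1nc(C(F)(F)F)c(C(=O)N/N=C/c2ccccc2C(F)(F)F)s1`, continues in the same spirit. The change is fluoro in place of hydrogen on an aromatic carbon, turning the 2-fluorophenyl group into a 2,6-difluorophenyl group. Since every measured change to this ring stayed within the scatter, the step from compound 3 to compound 4 is expected to be a 1.1-fold lower number from compound 3 to compound 4 (0.03 log units; within the scatter), with no direction favoured. Compound 4 is therefore estimated at 9.5 ug/mL, in a range from 5 ug/mL to 18 ug/mL.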

Compound 4, half-maximal inhibitory concentration: 19.6 ug/mL
The estimate for compound 4 lay 2.1-fold (0.31 log units) below the measured number; the whole stated range lies below it.
By their numbers in this assay, from the lowest: compounds 2, 1, 3 and 4 (each within the scatter of the next, the first and the last beyond it).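

Going by these compounds alone, with fluoro in place of hydrogen ortho to a large group, the 2,6-difluorophenyl group gives the first steps on this ring that go beyond the scatter in this assay: a 2.2-fold higher number from compound 2 to compound 4 (0.34 log units; beyond the scatter) and a 2.1-fold higher number from compound 1 to compound 4 (0.33 log units; beyond the scatter). Within the data shown here, both steps are modest, and the single change itself stays within the scatter, at a 1.9-fold higher number from compound 3 to compound 4 (0.29 log units; within the scatter), so compound 4 cannot be separated from compound 3 even though it stands apart from the other two. Nothing available here explains this difference.

From the compounds shown here alone, it remains open whether a methoxy group or an amine in place of this fluoro would give a number closer to compound 3 or to compound 4. Also open is where a plain phenyl group on the same carbonyl carbon would fall among these four compounds.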